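Swapping the group on the carbonyl: compound 2 to compound 3

This account rests on a few compounds, and the source may have more. Where it says the series, first, only, none or still open, it means among the compounds named here.

compound 1 `C=CC(=O)Nc1cccc(Oc2nc(Nc3ccn(C)n3)nc3c2CSCC3)c1`: 25800 nM
compound 2 `CCC/C=C/C(=O)Nc1cccc(Oc2nc(Nc3ccn(C)n3)nc3c2CSCC3)c1`: 17000 nM
compound 3 `C=C(C)C(=O)Nc1cccc(Oc2nc(Nc3ccn(C)n3)nc3c2CSCC3)c1`: not yet measured

In a functional assay on HeLa cells (Homo sapiens) for antiproliferative activity, read by MTT assay, with a stated time of 72 h (a higher number here means a weaker inhibitor, a lower number a stronger inhibitor), compound 2 gives 17000 nM, within the scatter of compound 1 at 25800 nM. Among the compounds with values here, these are the only two numbers so far.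

The next change is 1-methylethenyl in place of pent-1-en-1-yl on a carbonyl carbon. Within the data shown here, one measured step bears on it: a 1.5-fold lower number from compound 1 to compound 2 (0.18 log units; within the scatter), where pent-1-en-1-yl took the place of vinyl at the same carbonyl carbon. That step stayed within the scatter. Among the measured compounds shown here, no measurement yet covers 1-methylethenyl, so the evidence is thin, and no step beyond the scatter is expected in this assay. The expected change is a 1.2-fold higher number from compound 2 to compound 3 (0.09 log units; within the scatter). The estimate for compound 3 is 21000 nM, with an expected range of 9500 nM to 45000 nM.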

Compound 3, half-maximal inhibitory concentration: > 50000 nM
Compound 3 was reported as a limit; the forecaster's own chance of this, stated with the estimate: 8%; middle value at least 2.3-fold (0.37 log units) from the limit.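

Within the data shown here, at the carbonyl carbon whose other neighbour is the amide-type nitrogen, 1-methylethenyl in place of pent-1-en-1-yl gives in this assay an at least 2.9-fold higher number from compound 2 to compound 3 (0.46 log units; beyond the scatter), the first step at this place to lie beyond the scatter. For compound 3, > 50000 nM is a limit of the assay and not a number, and both new steps rest on it: the limit of > 50000 nM in this assay, at which 1 of the 3 values shown sits. Methyl in place of hydrogen on a double-bonded chain carbon bound to a carbonyl carbon gives an at least 1.9-fold higher number from compound 1 to compound 3 (0.28 log units; that floor lies within the scatter), a floor that does not yet separate the two compounds.

As far as these compounds go, the true size of both steps stays open, and with it whether that methyl alone matters. From the compounds shown here alone, how a chain carrying an amine, or a carboxylic acid, on this carbonyl carbon would read in this assay also remains open.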